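Bromo to Methyl: Estimating Compound 4's Antiproliferative Potency

A few compounds are considered here, and "the series" means these few. Any claim that something is new, unique, unknown or untested is made for them only; others in the source may bear on it.

Three compounds have been measured in a functional assay on SK-BR-3 cells (Homo sapiens) for antiproliferative activity, read by MTT assay, with a stated time of 72 h; on this read-out lower numbers stand for stronger inhibition and higher numbers for weaker inhibition:

Compound 1, `Cc1cc(NCCN2CCN(C)CC2)nc2ccc(NC(=O)c3ccc(Cl)c(Cl)c3)cc12`, gives 2690 nM.
Compound 2, `CCN1CCN(c2cc(C)c3cc(NC(=O)c4cccc(Br)c4)ccc3n2)CC1`, gives 13300 nM.
Compound 3, `Cc1cc(N2CCCCC2)nc2ccc(NC(=O)c3ccc(Cl)c(Cl)c3)cc12`, gives 42500 nM.

Among these three numbers, compound 2 stands second highest: compound 3 returns a higher number and compound 1 a lower one, so compound 2 sits between them in this assay. Among the compounds with values here, the only single-point comparison among the measured compounds is a 16-fold higher number from compound 1 to compound 3 (1.20 log units; beyond the scatter), a large step, but it concerns a different part of the shared core and says nothing about the amide side.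

Compound 4, `CCN1CCN(c2cc(C)c3cc(NC(=O)c4cccc(C)c4)ccc3n2)CC1`, differs from compound 2 in one place: methyl in place of bromo on an aromatic carbon. Within the data shown here, no measured pair touches this position, so there is no step to lean on. One small, uncharged group replaces another of the same size on the same aromatic carbon, and in the absence of any guiding comparison the expectation is a change of a 1.1-fold higher number from compound 2 to compound 4 (0.05 log units; within the scatter), within the scatter. Compound 4 is therefore estimated at 15000 nM, with a likely range of 5000 nM to 45000 nM.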

Compound 4, half-maximal inhibitory concentration: 13700 nM
Beside the measured number, compound 4's estimate is 1.1-fold (0.04 log units) above it; the measured number falls inside the stated range.
By their numbers in this assay, from the lowest: compound 1; then compounds 2 and 4 (each within the scatter of the next); then compound 3.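

The earlier compounds shown here offered no comparison at this position. Now, in this assay, the change from 3-bromophenyl to 3-methylphenyl gives a 1.0-fold higher number from compound 2 to compound 4 (0.01 log units; within the scatter) and leaves the two compounds indistinguishable, so on this pair, bromo and methyl, each a single heavy atom, can be exchanged at this aromatic carbon without a change this read-out can detect. Nothing at hand explains why the two groups behave alike.

This single pair cannot show whether the position accepts everything or only small uncharged groups, and an amine, a carboxylic acid or a longer chain on the same carbon could give a very different number. Also open, as far as these compounds go, is whether the same exchange would read alike elsewhere on this ring.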